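Swapping the Chlorothiazole Sulfonamide Ring for a Chlorophenyl

The compounds below may be only part of what the source reports. "The series", "measured", "known", "first", "only" and "open" are said of these compounds alone.

Compound 1 `CC1CCN(C2CCN(S(=O)(=O)c3sc(Cl)nc3C3CC3)CC2)CC1` in a functional assay on DLD-1 cells (Homo sapiens) for antiproliferative activity, read by CellTiter-Glo, with a stated time of 72 h (a lower number here means a stronger inhibitor, a higher number a weaker inhibitor), returns only > 5000 nM, a limit of the measurement rather than a number (the limit of > 5000 nM in this assay, at which 1 of the 3 values shown sits). Compound 2 `CC1CCN(C2CCN(S(=O)(=O)c3cnc(Cl)s3)CC2)CC1` gives 1800 nM, and compound 3 `CC(=O)Nc1ccc(S(=O)(=O)N2CCC(N3CCC(C)CC3)CC2)c2ccccc12` gives 1100 nM; the gap between these two lies within the scatter, so neither stands apart from the other. Among the measured compounds shown here, the one measured step, an at least 2.7-fold lower number from compound 1 to compound 2 (0.44 log units; beyond the scatter), concerns the cyclopropyl group and does not touch the ring attached to the sulfonyl sulfur. Compound 4 `CC1CCN(C2CCN(S(=O)(=O)c3cccc(Cl)c3)CC2)CC1` differs from compound 2 by 3-chlorophenyl in place of 2-chloro-1,3-thiazol-5-yl on a sulfonyl sulfur. For the measured compounds named here, no measured step covers this change, so compound 4 is expected near compound 2, with a step of about a 1.2-fold lower number from compound 2 to compound 4 (0.08 log units; within the scatter). The estimate for compound 4 is 1500 nM, ranging from 500 nM to 4500 nM.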

Compound 4, half-maximal inhibitory concentration: > 5000 nM
Compound 4: a limit, no number; the forecaster's own chance of this, stated with the estimate: 15%; at least 3.3-fold (0.52 log units) between middle value and limit.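

In this assay, the ring on the sulfonyl sulfur proves to matter, which the cyclopropyl step could not show: 3-chlorophenyl in place of 2-chloro-1,3-thiazol-5-yl gives an at least 2.7-fold higher number from compound 2 to compound 4 (0.44 log units; beyond the scatter), so the two rings are not interchangeable here. Compound 4 gives only a limit, so the step has a lower bound and no exact size: the limit of > 5000 nM in this assay, at which 2 of the 4 values shown sit.

As far as these compounds go, it remains open whether the hetero atoms of the thiazole or the place of the chlorine accounts for this step. Nor do the compounds shown tell how a pyridine ring or an unsubstituted phenyl on the sulfonyl sulfur would compare.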